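A few compounds are considered here, and "the series" means these few. Any claim that something is new, unique, unknown or untested is made for them only; others in the source may bear on it.

Among the compounds with values here, compound 2 `COc1ccc(C(=O)/C=C/c2cc(-c3cc(OC)c(OC)c(OC)c3)n[nH]2)cc1` stands at the lower of the two numbers so far: in a functional assay on U-251 cells (Homo sapiens) for cytotoxicity, read by sulforhodamine B assay, with a stated time of 48 h, tested at 10 uM (a lower number here means a stronger effect, a higher number a weaker effect of the compound at the concentration tested), compound 2 gives -98%, the stronger effect of the pair. Within the data shown here, its only neighbour is compound 1 `COc1cc(-c2cc(/C=C/C(=O)c3ccc(Cl)c(Cl)c3)[nH]n2)cc(OC)c1OC`, which in this assay gives 48%. Among the measured compounds shown here, the one measured step joining them, a number 146 percentage points lower from compound 1 to compound 2 (beyond the scatter), is the sole guide for what follows.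

Compound 3 `COc1cc(-c2cc(/C=C/C(=O)c3ccc(F)c(F)c3)[nH]n2)cc(OC)c1OC` has not yet been measured. It differs from compound 2 by 3,4-difluorophenyl in place of 4-methoxyphenyl on a carbonyl carbon. This change runs in the opposite sense to the measured step: the 4-methoxyphenyl that entered from compound 1 to compound 2 now leaves, and a 3,4-difluorophenyl enters in the place where compound 1 carried a 3,4-dichlorophenyl. Since that step in this assay was large and beyond the scatter, a large step back upward toward the number of compound 1 is expected for compound 3, though compound 1 is the only anchor and a 3,4-difluorophenyl is not a 3,4-dichlorophenyl. Compound 3 is therefore estimated at 30%, with a range from -60% to 90%, a step of a number 128 percentage points higher from compound 2 to compound 3 (beyond the scatter) that is expected, not known.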

Compound 3, a percentage reported as activity, at one concentration (the size of the read-out at that concentration, not a potency): 7%
Compound 3: middle estimate off by 23 percentage points, on the high side; the measured number falls inside the stated range.
By their numbers in this assay, from the lowest: compound 2; then compound 3; then compound 1.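

At the place on a carbonyl carbon whose other neighbours are a double-bonded chain carbon, this assay now shows three clearly separated levels rather than two, and the new compound falls at neither of the earlier ones. Replacing the 4-methoxyphenyl with a 3,4-difluorophenyl gives a number 105 percentage points higher from compound 2 to compound 3 (beyond the scatter), so among these three compounds the 4-methoxyphenyl of compound 2 remains the aryl group with the strongest effect, and the two halogen-bearing groups do not recover it. The two halogen-bearing groups are not interchangeable either: 3,4-difluorophenyl in place of 3,4-dichlorophenyl gives a number 41 percentage points lower from compound 1 to compound 3 (beyond the scatter), which shows that the read-out at this position depends on which halogen the ring carries, not only on whether the ring carries halogen, although nothing given here accounts for either step.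

The compounds shown leave open whether the low number of compound 2 depends on the methoxy group itself, since an unsubstituted phenyl or a 4-hydroxyphenyl at this carbonyl carbon would be needed to separate that group from the ring. They also leave open how a 3,4-dimethoxyphenyl, or a ring carrying an amine, would fall against these three levels.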